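Swapping Trifluoromethyl for Methoxy on the Pendant Ring

The source may report more compounds than this note shows. Statements on the series, on what has been measured and on what is new or still open speak of the compounds shown alone.

Three measured compounds share one core and differ only in a small aromatic group at its edge. Compound 1 `COc1cc2c(Oc3ccc(NC(=O)c4cc(-c5ccc(C)cc5)ccn4)cc3F)ccnc2cc1OCCCN1CCCC1` carries a 4-methylphenyl group and gives 440 nM in a functional assay on MKN-45 cells (Homo sapiens) for cytotoxicity, read by MTT assay, with a stated time of 72 h; a higher number here means a weaker inhibitor, a lower number a stronger inhibitor. Compound 2 `COc1cc2c(Oc3ccc(NC(=O)c4cc(-c5ccccc5C)ccn4)cc3F)ccnc2cc1OCCCN1CCCC1` carries a 2-methylphenyl group and gives 440 nM in this assay. Compound 3 `COc1cc2c(Oc3ccc(NC(=O)c4cc(-c5ccc(C(F)(F)F)cc5)ccn4)cc3F)ccnc2cc1OCCCN1CCCC1` carries a 4-(trifluoromethyl)phenyl group and gives 260 nM in this assay. On the numbers as written compound 3 is separated from neither companion: a 1.7-fold lower number from compound 1 to compound 3 (0.23 log units; within the scatter) and a 1.7-fold lower number from compound 2 to compound 3 (0.23 log units; within the scatter), and between the other two no change at the digits printed from compound 1 to compound 2 (within the scatter).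

Compound 4 `COc1ccc(-c2ccnc(C(=O)Nc3ccc(Oc4ccnc5cc(OCCCN6CCCC6)c(OC)cc45)c(F)c3)c2)cc1` keeps everything except the group on that pendant ring: methoxy in place of trifluoromethyl on an aromatic carbon. Among the compounds with values here, the step that bears most directly on this change is the one at the same position, where a methyl became a trifluoromethyl, a 1.7-fold lower number from compound 1 to compound 3 (0.23 log units; within the scatter); the other two steps, which also vary only this pendant ring, were likewise within the scatter. Nothing seen so far suggests that changing this group moves this assay beyond the usual scatter, so compound 4 is expected to show a 1.3-fold higher number from compound 3 to compound 4 (0.13 log units; within the scatter). The estimate for compound 4 is therefore 350 nM, with a plausible range from 150 nM to 900 nM.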

Compound 4, half-maximal inhibitory concentration: 150 nM
Estimate against measurement, compound 4: 2.3-fold (0.37 log units) above; low and high end bracket the measured number.
By their numbers in this assay, from the lowest: compounds 4, 3, 1 and 2 (each within the scatter of the next, the first and the last beyond it).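

In this assay the exchange of trifluoromethyl for methoxy is itself a small step, a 1.7-fold lower number from compound 3 to compound 4 (0.24 log units; within the scatter) and so compound 3 and compound 4 cannot be told apart at this position. The new information lies in the comparisons with the methyl-bearing compounds, where the pendant ring first produces differences larger than the usual scatter: a 2.9-fold lower number from compound 1 to compound 4 (0.47 log units; beyond the scatter) for the change from methyl to methoxy on the same aromatic carbon and a 2.9-fold lower number from compound 2 to compound 4 (0.47 log units; beyond the scatter) for the change from 2-methylphenyl to 4-methoxyphenyl. These differences are modest, but they show that a change on this ring can move the number in this cell assay, while compound 3 remains too close to all three companions to place it firmly with either side; no measurement shown explains the separation.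

On these data alone, it remains open whether a hydroxyl, an amine, a carboxylic acid or a longer chain such as ethoxy on that same aromatic carbon would extend this separation or leave the number within the scatter. These four compounds also cannot show whether the methoxy result would hold with any change to the shared core.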